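One stereocentre inverted: from compound 2 to compound 3

A few compounds are considered here, and "the series" means these few. Any claim that something is new, unique, unknown or untested is made for them only; others in the source may bear on it.

Compound 1 `COc1ccc(CCCC(=O)O)cc1C1OC(C)C(O)C(O)C1O` is the open-chain acid of the pair. In an assay on isolated protein for binding affinity to E-selectin (Homo sapiens), read by ELISA (on this read-out lower numbers stand for stronger inhibition and higher numbers for weaker inhibition), compound 1 gives only the assay limit, > 1000000 nM. Compound 2 `COc1ccc(C2(C(=O)O)CCCCC2)cc1[C@H]1O[C@@H](C)[C@@H](O)[C@H](O)[C@@H]1O` places the acid on a saturated ring. In this assay compound 2 likewise gives only a limit, > 1000000 nM. Compound 2 therefore stands exactly where every value shown stands (the limit of > 1000000 nM in this assay, at which 2 of the 2 values shown sit). Compound 3 `COc1ccc(C2(C(=O)O)CCCCC2)cc1[C@H]1O[C@@H](C)[C@H](O)[C@H](O)[C@@H]1O` differs from compound 2 only in configuration: the two compounds have the same atoms and bonds and differ only in configuration as drawn: 1 of 5 stereo elements differ; a stereocentre at a saturated ring carbon is drawn S in compound 2 and R in compound 3. Expected is a step of a number no higher from compound 2 to compound 3 (the limit leaves the size open) of no size beyond the scatter. Compound 3 is expected at 1000000 nM, with a range of 300000 nM to 3000000 nM.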

Compound 3, half-maximal inhibitory concentration: > 1000000 nM
Compound 3: a limit, no number; the forecaster's own chance of this, stated with the estimate: 85%; the middle value lies on the limit itself.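

Compound 2 and compound 3 both give only a limit in this assay, so no step can be read between them. The compounds shown leave open whether inverting this stereocentre changes inhibition at all.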